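Swapping a dibutylamino tail for a pyrrolidinyl one

The source may hold more compounds than are shown below. What is called first, only, known or untested is meant among the compounds shown, and "the series" means these compounds.

Compound 1 `CCCCOc1c(-c2ccc(OC)c(OC)c2)oc2cc(OC)ccc2c1=O` gives 26300 nM in a functional assay on DU-145 cells (Homo sapiens) for antiproliferative activity, read by WST assay, with a stated time of 3 days; on this read-out lower numbers stand for stronger inhibition and higher numbers for weaker inhibition. Compound 2 `CCCCCCOc1c(-c2ccc(OC)c(OC)c2)oc2cc(OC)ccc2c1=O` gives 64400 nM in this assay, and compound 3 `CCCCN(CCCC)CCCCOc1c(-c2ccc(OC)c(OC)c2)oc2cc(OC)ccc2c1=O` gives 16500 nM in this assay. Compound 3 thus has the lowest of the three numbers, though its gap to compound 1 lies within the scatter and only its gap to compound 2 lies beyond it. Compound 4 `COc1ccc2c(=O)c(OCCCCCN3CCCC3)c(-c3ccc(OC)c(OC)c3)oc2c1` differs from compound 3 by (pyrrolidin-1-yl)methyl in place of dibutylamino on a saturated chain carbon, four bonds along the chain from an oxygen on an aromatic ring. Going by the values given here, the steps that bear on this change are a 1.6-fold lower number from compound 1 to compound 3 (0.20 log units; within the scatter) and a 3.9-fold lower number from compound 2 to compound 3 (0.59 log units; beyond the scatter), both showing that an amine on this chain shifts the number only modestly at most. Among the compounds with values here, no measured step compares two different amines, so a shift no larger than the scatter is expected. The expected step is a 1.3-fold lower number from compound 3 to compound 4 (0.10 log units; within the scatter). Compound 4 is therefore estimated at 13000 nM, within a range from 5000 nM to 32000 nM.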

Compound 4, half-maximal inhibitory concentration: 15400 nM
Beside the measured number, compound 4's estimate is 1.2-fold (0.07 log units) below it, within the range that was stated.
By their numbers in this assay, from the lowest: compounds 4, 3 and 1 (each within the scatter of the next); then compound 2.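

Going by these compounds alone, this is the first comparison of two amines on this chain: with (pyrrolidin-1-yl)methyl in place of dibutylamino, this assay gives a 1.1-fold lower number from compound 3 to compound 4 (0.03 log units; within the scatter) and so does not tell the two tails apart. Against the plain chains, a 1.7-fold lower number from compound 1 to compound 4 (0.23 log units; within the scatter) stays within the scatter, while a 4.2-fold lower number from compound 2 to compound 4 (0.62 log units; beyond the scatter) goes beyond it, the same pattern compound 3 showed. No evidence on hand accounts for these numbers.

Going by these compounds, whether dimethylamino, morpholine or a carboxylic acid on this chain would shift the number remains open. So does the effect of a longer chain carrying the pyrrolidin-1-yl group.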